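Fluorine on the Five-Membered Ring: Compound 3 to Compound 4

The source may hold more compounds than are shown below. What is called first, only, known or untested is meant among the compounds shown, and "the series" means these compounds.

Three measured compounds share a core built from an amino-bearing five-membered aromatic ring joined to a second aromatic ring that carries a trifluoromethyl group and a fluorine. Compound 1 `Nc1nc(-c2cccc(C(F)(F)F)c2F)cs1` is one arrangement of those two groups, and in a functional assay for agonist activity at thrombopoietin receptor (Homo sapiens) (a higher number here means that more compound is needed for the effect, a lower number that less compound is needed), compound 1 gives 57 nM. Compound 2 `Nc1nc(-c2ccc(C(F)(F)F)cc2F)cs1` is a second arrangement, and in this assay compound 2 gives 260 nM. Compound 3 `Nc1nc(-c2ccc(F)c(C(F)(F)F)c2)cs1` is a third arrangement, and in this assay compound 3 gives 100 nM. Among these three numbers compound 3 stands second highest: its value and that of compound 1 lie within the scatter of each other and cannot be told apart, while compound 2 has a number that is higher beyond the scatter.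

Compound 4 `Nc1nc(-c2ccc(F)c(C(F)(F)F)c2)c(F)s1` has not yet been measured. It differs from compound 3 in one place: fluoro in place of hydrogen on an aromatic carbon. All three measured compounds differ from one another only on the attached ring, so none of them shows what a change on the five-membered ring does. A single fluorine in place of hydrogen gives no ground to expect a large shift in this assay in either direction. Compound 4 is therefore expected to give about 100 nM in this assay, within a range from 35 nM to 300 nM. The expected step of no change at the digits printed from compound 3 to compound 4 (within the scatter) is none beyond the scatter.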

Compound 4, half-maximal effective concentration: 89 nM
Compound 4: middle estimate off by 1.1-fold (0.05 log units), on the high side; measured number inside the range.
By their numbers in this assay, from the lowest: compounds 1, 4 and 3 (each within the scatter of the next); then compound 2.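

This result gives the first reading from the five-membered ring itself, since compounds 1, 2 and 3 differ only on the attached ring. In this assay, fluoro in place of hydrogen on the aromatic carbon next to the ring sulfur gives a 1.1-fold lower number from compound 3 to compound 4 (0.05 log units; within the scatter), so the two numbers cannot be told apart and this carbon can carry a fluorine without a measurable loss in this assay. Nothing available bears on why the fluorine leaves the number within the scatter.

A hydrogen and a fluorine are the only two substituents shown at this carbon, and fluoro adds just one heavy atom, so the result does not tell how far this position would accept something bigger or different in kind, such as a methyl group, an amine or a carboxylic acid. It also leaves open whether the same fluorine would behave alike on the attached-ring arrangement of compound 1 or compound 2, as the swap appears here on the arrangement of compound 3 alone.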